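Bromo in place of aromatic hydrogen: compound 4 expected

The source may report more compounds than this note shows. Statements on the series, on what has been measured and on what is new or still open speak of the compounds shown alone.

For the measured compounds named here, in an ADME assay on RAW264.7 cells (Mus musculus) for cytotoxicity, read by MTT assay, with a stated time of 18 h (a lower number here means that less compound is tolerated, a higher number that more compound is tolerated), compound 1 `C=C1C(=O)OC[C@H]1CCOC(=O)Nc1ccccc1` gives 14800 nM, the lowest of the three numbers so far, though no gap to its neighbours is beyond the scatter. Compound 3 `C=C1C(=O)OC[C@H]1CCOC(=O)Nc1ccccc1F` gives 17400 nM and compound 2 `C=C1C(=O)OC[C@@H]1CCOC(=O)Nc1ccccc1` gives 22300 nM. The steps are a 1.2-fold higher number from compound 1 to compound 3 (0.07 log units; within the scatter) and a 1.5-fold higher number from compound 1 to compound 2 (0.18 log units; within the scatter); for the second pair, the fact that compounds 1 and 2 differ only in the configuration as drawn is all that separates the two structures, and the numbers sit together.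

Compound 4 `C=C1C(=O)OC[C@H]1CCOC(=O)Nc1ccc(Br)cc1` differs from compound 1 by bromo in place of hydrogen on an aromatic carbon. Going by the values given here, the one measured step on the same six-membered aromatic ring is fluoro in place of hydrogen, a 1.2-fold higher number from compound 1 to compound 3 (0.07 log units; within the scatter), which did not move the number beyond the scatter. Among the compounds with values here, no measured step exchanges hydrogen for a heavier halogen on this ring, so the expectation rests on that single step and on the narrow spread of the three values in hand.

The step from compound 1 to compound 4 is therefore expected to be a 1.1-fold higher number from compound 1 to compound 4 (0.03 log units; within the scatter), not beyond the scatter. In this assay compound 4 is expected to give 16000 nM, with a range from 8000 nM to 32000 nM.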

Compound 4, half-maximal cytotoxic concentration: 8470 nM
Compound 4: middle estimate off by 1.9-fold (0.28 log units), on the high side; the range from low to high includes it.
By their numbers in this assay, from the lowest: compounds 4, 1, 3 and 2 (each within the scatter of the next, the first and the last beyond it).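

In this assay, bromo on an aromatic carbon para to a large group gives a 1.7-fold lower number from compound 1 to compound 4 (0.24 log units; within the scatter), so this place on the six-membered aromatic ring accepts a single bromine atom without a step beyond the scatter. For the compounds shown here, until now, the only exchange of hydrogen on this ring was fluoro, a 1.2-fold higher number from compound 1 to compound 3 (0.07 log units; within the scatter), and compound 4 extends that reading from fluoro to bromo, with both halogen steps within the scatter, though each rests on a single pair of compounds. Nothing in hand bears on why the bromo step has this size, and the scatter leaves no change in tolerated concentration to explain.

Open, as far as these compounds go, is whether an amine, a carboxylic acid or a longer chain at this same place on the core of compound 1 would also stay within the scatter in this assay. Going by these compounds alone, also open is whether bromo at this place gives a similar step on the core of compound 2, the other drawn configuration, since every halogen step so far starts from compound 1.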